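Fluorines on the aryl ring of compound 1

A few compounds are considered here, and "the series" means these few. Any claim that something is new, unique, unknown or untested is made for them only; others in the source may bear on it.

Measured so far, with the largest response reached:
compound 1 `O=C(O)Cc1sc(C(c2ccccc2)c2ccccc2)nc1-c1ccccc1` — 80%
compound 2 `Cc1nc(-c2ccc(Cl)cc2)c(CC(=O)O)s1` — 50%
compound 3 `O=C(O)Cc1sc(C(c2ccc(F)cc2)c2ccc(F)cc2)nc1-c1cc(F)cc(F)c1` — 80%

In an in vitro functional assay on HEK285-7 cells for antagonist activity at prostaglandin D2 receptor 2 (Homo sapiens), read by BRET and beta-arrestin recruitment (a higher number here means a larger maximal response, a lower number a smaller maximal response), compound 1 gives 80% and stands level with compound 3 at the digits shown, the two together forming the upper end of the three numbers. Compound 2 gives 50%, a number below compound 1 and beyond the usual scatter; compound 2 differs from compound 1 in more than one place, so no single step can be read from that pair. Compound 3, which carries fluorines on all three aryl groups, differs in several places as well and gives 80%.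

The next compound, compound 4 `O=C(O)Cc1sc(C(c2ccccc2)c2ccccc2)nc1-c1ccc(F)c(F)c1`, changes compound 1 in one place only: 3,4-difluorophenyl in place of phenyl on an aromatic carbon. Going by the values given here, no step of this kind has been measured. Among the compounds with values here, the only guide is compound 3, whose fluorinated aryl groups leave the value at 80%, no different from compound 1 within the scatter. On that basis the step of a number 2 percentage points lower from compound 1 to compound 4 (within the scatter) is expected to be small, within the scatter, in no clear direction. Compound 4 is accordingly estimated at 78%, with a range from 62% to 92%.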

Compound 4, largest response reached (reported as efficacy), in percent of the reference or control that the assay uses: 80%
The estimate for compound 4 lay 2 percentage points below the measured number, and the stated range covers the measured number.
By their numbers in this assay, from the lowest: compound 2; then compounds 1, 3 and 4 (each within the scatter of the next).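

In this assay, 3,4-difluorophenyl in place of phenyl on an aromatic carbon next to the ring nitrogen gives no change at the digits printed from compound 1 to compound 4 (within the scatter), so the largest response reached holds at this position with the two fluorines added. Going by these compounds alone, the earlier compounds offered no step that differs in one place, so this is the first reading of this position on its own. No supporting measurement bears on the reason for this result.

Still open, on these data alone, is whether a single fluorine, or a group of another kind such as methoxy, nitrile or trifluoromethyl on the same phenyl, would leave the response as it stands. Also open, as far as these compounds go, is how a change at the carboxymethyl group, such as a longer chain carrying the carboxylic acid, would read against compound 1 in this assay.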